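The source may hold more compounds than are shown below. What is called first, only, known or untested is meant among the compounds shown, and "the series" means these compounds.

Compound 1 `COc1cc(-c2ccnc3cc(-c4ccc(F)cc4)nn23)cc(OC)c1OC` stands highest of the three numbers in a functional assay on HCT-116 cells (Homo sapiens) for inhibition, read by CCK-8 assay, with a stated time of 48 h (on this read-out lower numbers stand for stronger inhibition and higher numbers for weaker inhibition), where compound 1 gives 5030 nM. Compound 2 `COc1cc(-c2ccnc3cc(-c4ccc(N(C)C)cc4)nn23)cc(OC)c1OC` gives 2050 nM and compound 3 `COc1cc(-c2ccnc3cc(-c4ccc(C(C)=O)cc4)nn23)cc(OC)c1OC` gives 4390 nM. The measured steps are a 2.5-fold lower number from compound 1 to compound 2 (0.39 log units; beyond the scatter), a 1.1-fold lower number from compound 1 to compound 3 (0.06 log units; within the scatter) and a 2.1-fold higher number from compound 2 to compound 3 (0.33 log units; beyond the scatter). Compound 4 `COc1cc(-c2ccnc3cc(-c4ccc5cnn(C)c5c4)nn23)cc(OC)c1OC` differs from compound 1 in one place: 1-methyl-1H-indazol-6-yl in place of 4-fluorophenyl on an aromatic carbon. All three measured steps exchange the group at this same aromatic carbon and none exceeds a modest size, so a step no larger than modest is expected in this assay for compound 4, most likely toward a lower number. The estimate for compound 4 is 3200 nM, ranging from 1100 nM to 9500 nM, which is expected to mean a 1.6-fold lower number from compound 1 to compound 4 (0.20 log units; within the scatter).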

Compound 4, half-maximal inhibitory concentration: 2440 nM
Compound 4: middle estimate off by 1.3-fold (0.12 log units), on the high side; measured number inside the range.
By their numbers in this assay, from the lowest: compounds 2, 4, 3 and 1 (each within the scatter of the next, the first and the last beyond it).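

Replacing the single 4-fluorophenyl ring with the two-ring 1-methyl-1H-indazol-6-yl group at this aromatic carbon gives a 2.1-fold lower number from compound 1 to compound 4 (0.31 log units; beyond the scatter) in this assay, so this position accepts a larger group with 2 hydrogen-bond acceptors. Against the two other phenyl groups, the results are a 1.8-fold lower number from compound 3 to compound 4 (0.26 log units; within the scatter) and a 1.2-fold higher number from compound 2 to compound 4 (0.08 log units; within the scatter), both within the scatter. Nothing available explains these steps.

The compounds shown leave open whether the methyl on the indazole matters, and how an unmethylated indazole, a morpholine or a carboxylic acid would behave at this carbon. As far as these compounds go, the effect of changes elsewhere on the shared core also remains open.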